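Fluoro for chloro on the benzylamide of compound 2

This account rests on a few compounds, and the source may have more. Where it says the series, first, only, none or still open, it means among the compounds named here.

Among the measured compounds shown here, in a functional assay on HCT-116 cells (Homo sapiens) for cytotoxicity, read by MTT assay, with a stated time of 72 h (a higher number here means a weaker inhibitor, a lower number a stronger inhibitor), compound 2 `N[C@H]1CC[C@H](Nc2c(C(=O)NCc3ccc(Cl)cc3)nc(Br)c3cccnc23)CC1` gives 4000 nM, one of only two numbers recorded here. Compound 3 `CS(=O)(=O)NCCCCCCN(c1nc(C(=O)NCc2ccc(F)cc2)c(O)c2ncccc12)S(C)(=O)=O` gives 3000 nM in this assay, a value lying within the usual scatter of compound 2, so the two cannot be ranked. Compound 1 `O=C(NCc1ccc(F)cc1)c1nc(Br)c2cccnc2c1NCCCNc1c(C(=O)NCc2ccc(F)cc2)nc(Br)c2cccnc12` reaches only the assay limit of > 20000 nM in this assay, as the limit of > 20000 nM in this assay, at which 1 of the 3 values shown sits, records. Compound 4 `N[C@H]1CC[C@H](Nc2c(C(=O)NCc3ccc(F)cc3)nc(Br)c3cccnc23)CC1` has not yet been measured. It differs from compound 2 by fluoro in place of chloro on an aromatic carbon. For the measured compounds named here, no measured pair in this set shares that change, so nothing here sets its size; a step no larger than the scatter is expected in this assay, in either direction. For compound 4 the expected value is 5000 nM, with a range from 2000 nM to 12000 nM. That corresponds to an expected step of a 1.3-fold higher number from compound 2 to compound 4 (0.10 log units; within the scatter).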

Compound 4, half-maximal inhibitory concentration: 7000 nM
Beside the measured number, compound 4's estimate is 1.4-fold (0.15 log units) below it; measured number inside the range.
By their numbers in this assay, from the lowest: compounds 3, 2 and 4 (each within the scatter of the next, the first and the last beyond it). At a limit, above all of these: compound 1.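

Among the compounds shown here, this is the first pair here that differs in one place, and in this assay going from 4-chlorobenzyl to 4-fluorobenzyl gives a 1.8-fold higher number from compound 2 to compound 4 (0.24 log units; within the scatter). The two compounds cannot be ranked, so this read-out does not tell fluoro from chloro at this position. Nothing measured here bears on the size of this step. Still open, on these data alone, is whether a different kind of group at this place, such as methoxy or a carboxylic acid, would move the number beyond the scatter. Also open, as far as these compounds go, is whether the same exchange would read alike with a longer chain in place of the ring carrying the amine.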